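A few compounds are considered here, and "the series" means these few. Any claim that something is new, unique, unknown or untested is made for them only; others in the source may bear on it.

Measured compounds:
compound 1, `CS(=O)(=O)Cc1cccc(C#Cc2cc(Cl)ccc2OCC(=O)O)c1`, 48 nM
compound 2, `CN(C)C(=O)c1cccc(C#Cc2cc(Cl)ccc2OCC(=O)O)c1`, 52 nM
compound 3, `CS(=O)(=O)c1ccc(F)c(C#Cc2cc(Cl)ccc2OCC(=O)O)c1`, 3.3 nM

Of the compounds shown here, three on a shared core have been tested in an assay on CHO cells for displacement of a labelled ligand from prostaglandin D2 receptor 2 (Homo sapiens), read by scintillation counting; a lower number here means a stronger inhibitor, a higher number a weaker inhibitor. For the measured compounds named here, compound 1 gives 48 nM and compound 2 gives 52 nM; the single one-place step among them, a 1.1-fold higher number from compound 1 to compound 2 (0.03 log units; within the scatter), stays within the scatter. Compound 3 gives 3.3 nM, the lowest of the three numbers, and its gap to compound 1 and to compound 2 lies beyond the scatter in both cases.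

Compound 4, `CS(=O)(=O)c1cccc(C#Cc2cc(Cl)ccc2OCC(=O)O)c1`, has not yet been measured. It differs from compound 3 in one place: hydrogen in place of fluoro on an aromatic carbon. Going by the values given here, no measured step removes a fluoro, so the only step at hand, a 1.1-fold higher number from compound 1 to compound 2 (0.03 log units; within the scatter), bears on it just indirectly: it shows that a change on the outer ring can leave this assay unmoved, while compound 3 shows that the fluoro-bearing methylsulfonyl ring gives a far lower number than either of the other two. How much of that gap rests on the fluoro alone cannot be separated out from these data. For compound 4 the estimate is 8 nM, with a range of 3 nM to 25 nM. That estimate means an expected 2.4-fold higher number from compound 3 to compound 4 (0.38 log units; beyond the scatter), a rise that may stay within the scatter.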

Compound 4, inhibition constant: 15 nM
Beside the measured number, compound 4's estimate is 1.9-fold (0.27 log units) below it; the range from low to high includes it.
By their numbers in this assay, from the lowest: compound 3; then compound 4; then compounds 1 and 2 (each within the scatter of the next).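

Removing the fluoro from the aromatic carbon para to the methylsulfonyl group and ortho to a large group has a real effect in this assay, with a 4.5-fold higher number from compound 3 to compound 4 (0.66 log units; beyond the scatter), so this one substituent accounts for part of the low number of compound 3. The fluoro does not account for all of the advantage, however, as the methylsulfonyl group still gives lower numbers without it: replacing (methylsulfonyl)methyl gives a 3.2-fold lower number from compound 1 to compound 4 (0.51 log units; beyond the scatter), and replacing dimethylcarbamoyl gives a 3.5-fold lower number from compound 2 to compound 4 (0.54 log units; beyond the scatter), whereas exchanging those two groups for each other gave only a 1.1-fold higher number from compound 1 to compound 2 (0.03 log units; within the scatter). No measurement at hand explains any of these steps.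

The compounds shown compare only hydrogen and fluoro at this carbon, so it remains open how a chloro, methyl or methoxy group there would read in this assay. From the compounds shown here alone, it is also open whether adding a fluoro to the aromatic ring of compound 1 or compound 2 would lower their numbers as well, or whether its benefit is tied to the methylsulfonyl group of compound 3.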